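Chain-Length Steps Across a Shared Core Pair

The source may report more compounds than this note shows. Statements on the series, on what has been measured and on what is new or still open speak of the compounds shown alone.

Of the compounds shown here, three have been measured in a functional assay on the whole organism for agonist activity, with Rattus norvegicus as the target; on this read-out higher numbers stand for an effect only at larger amounts of compound and lower numbers for an effect already at smaller amounts. Compound 2 `c1ccc2c(c1)CC2CCCN1CCN(c2cccc3c2OCCO3)CC1` gives 10 mg/kg in this assay. Compound 1 `c1ccc2c(c1)CC2CCCCN1CCN(c2cccc3c2OCCO3)CC1` is recorded only as a limit of the assay, > 10 mg/kg. The change from compound 2 to compound 1 is a group of 9 heavy atoms (9 carbon; one four-membered non-aromatic ring of carbon only, one six-membered aromatic ring of carbon only) in place of a group of 8 heavy atoms (8 carbon; one four-membered non-aromatic ring of carbon only, one six-membered aromatic ring of carbon only), on a saturated chain carbon, three bonds along the chain from an amine nitrogen in a ring; the step it made is a number no lower from compound 2 to compound 1 (the limit leaves the size open), and the limit of > 10 mg/kg in this assay, at which 2 of the 3 values shown sit, marks where compound 1 sits. Compound 3 `c1ccc2c(c1)CC2CN1CCN(c2cccc3c2OCCCO3)CC1` likewise gives only a limit of the assay, > 10 mg/kg. The difference between the core of compound 2 and the core of compound 3 is not broken down here. Compound 4 `c1ccc2c(c1)CC2CCN1CCN(c2cccc3c2OCCCO3)CC1` is not yet measured; it differs from compound 3 by a group of 9 heavy atoms (9 carbon; one four-membered non-aromatic ring of carbon only, one six-membered aromatic ring of carbon only) in place of a group of 8 heavy atoms (8 carbon; one four-membered non-aromatic ring of carbon only, one six-membered aromatic ring of carbon only), on a saturated chain carbon bound to an amine nitrogen in a ring, the same kind of change as from compound 2 to compound 1, though the place differs: on a saturated chain carbon bound to an amine nitrogen in a ring, rather than three bonds along the chain from an amine nitrogen in a ring. The step expected from compound 3 to compound 4 is a step that the limit leaves unreadable from compound 3 to compound 4, resting on the earlier step of a number no lower from compound 2 to compound 1 (the limit leaves the size open). Compound 4 is therefore estimated to give about 15 mg/kg in this assay, between 7 mg/kg and 40 mg/kg, and most likely reported only as a limit.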

Compound 4, minimum effective dose: 40 mg/kg
Compound 4: the middle estimate sits 2.7-fold (0.43 log units) below what was measured, within the range that was stated.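

No new step can be read from compound 3 to compound 4 in this assay: compound 3 is recorded only as a limit of the assay, > 10 mg/kg. The compounds shown leave open how large the change from the group of 8 heavy atoms to the group of 9 heavy atoms is on either core, and whether it runs the same way on both.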